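A Pyridin-2-yl Ketone Replaces the Fused Ring

A few compounds are considered here, and "the series" means these few. Any claim that something is new, unique, unknown or untested is made for them only; others in the source may bear on it.

In an assay on isolated protein for inhibition of Fatty-acid amide hydrolase 1 (Homo sapiens) (a higher number here means a weaker inhibitor, a lower number a stronger inhibitor), compound 2 `CCCCCCCC/C=C\CCCCCCC(=O)c1nc2cnccc2o1` gives 7.2 nM, the lowest number among the measured compounds. Compound 3 `CCCCCCCC/C=C\CCCCCCC(=O)c1ncc(-c2ccco2)o1` gives 54 nM in this assay, a higher number than compound 2. Compound 1 `O=C(CCCCCCc1ccccc1)c1nnn[nH]1` reaches only the limit > 1000 nM in this assay, which is a limit of the assay and not a measured number; this is the limit of > 1000 nM in this assay, at which 1 of the 3 values shown sits.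

Compound 4 `CCCCCCCC/C=C\CCCCCCC(=O)c1ccccn1` differs from compound 2 at the carbonyl carbon: a group of 6 heavy atoms (5 carbon, 1 nitrogen; one six-membered aromatic ring with 1 hetero atom) in place of a group of 9 heavy atoms (6 carbon, 2 nitrogen, 1 oxygen; one five-membered aromatic ring with 2 hetero atoms, one six-membered aromatic ring with 1 hetero atom), on a carbonyl carbon. Among the measured compounds shown here, no step between two measured compounds matches this change, so no measured step can be pointed to for it. The account expects the step to raise the number in this assay, well beyond the scatter, since the fused bicyclic group of compound 2 is lost and the compound 1 limit > 1000 nM shows that a small heterocycle on the carbonyl can leave inhibition weak.

Compound 4 is therefore expected to give about 600 nM in this assay, within a range of 100 nM to 5000 nM. The estimated step of an 83-fold higher number from compound 2 to compound 4 (1.92 log units; beyond the scatter) is toward weaker inhibition.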

Compound 4, inhibition constant: > 100000 nM
Compound 4 was reported as a limit (the forecaster's own chance of this, stated with the estimate: 20%); middle value at least 160-fold (2.22 log units) from the limit.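

With the chain and the carbonyl carbon unchanged, putting pyridin-2-yl in place of the two-ring group of compound 2 gives an at least 13000-fold higher number from compound 2 to compound 4 (4.14 log units; beyond the scatter) in this assay. Compound 4 stands at a limit of the assay, which is not a measured number: the limit of > 100000 nM in this assay, at which 1 of the 4 values shown sits. Among the compounds shown here, this is the only readable step at this position, and it shows that a six-membered aromatic ring with 1 hetero atom on this carbonyl carbon does not keep the inhibition seen with compound 2.

The compounds shown do not tell which part of the group lost from compound 2 accounts for the step. On these data alone, whether a pyridin-3-yl group on the same carbonyl carbon, or a five-membered aromatic ring carrying a carboxylic acid, would bring inhibition back also remains open.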